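Sulfonamide to benzamide on the three-carbon linker

The compounds below may be only part of what the source reports. "The series", "measured", "known", "first", "only" and "open" are said of these compounds alone.

Measured so far:
compound 1 `O=S(=O)(NCCCNc1nccc(-c2c(-c3cccc(F)c3)nc3sccn23)n1)c1cccc(F)c1`, a functional assay on A-375 cells (Homo sapiens) for cytotoxicity, read by MTT assay (on this read-out lower numbers stand for stronger inhibition and higher numbers for weaker inhibition), 13700 nM
compound 2 `O=S(=O)(NCCNc1nccc(-c2c(-c3cccc(F)c3)nc3sccn23)n1)c1ccc(Cl)cc1`, this assay 18600 nM

Among the compounds with values here, compound 2 sits within the usual scatter of compound 1; the only measured step, a 1.4-fold higher number from compound 1 to compound 2 (0.13 log units; within the scatter), changes both the chain length and the sulfonyl aryl at once and gives no separable lead. Compound 3 `O=C(NCCCNc1nccc(-c2c(-c3cccc(F)c3)nc3sccn23)n1)c1ccc(Cl)cc1` is not yet measured. It differs from compound 2 by (((4-chlorophenyl)carbonyl)amino)methyl in place of ((4-chlorophenyl)sulfonyl)amino on a saturated chain carbon, two bonds along the chain from a nitrogen on an aromatic ring. Within the data shown here, no measured pair compares a carbonyl with a sulfonyl at this place, so the step from compound 2 to compound 3 rests on the chain-length change alone, which stayed within the scatter in the step from compound 1 to compound 2. For compound 3 the expected step is therefore a 1.6-fold lower number from compound 2 to compound 3 (0.19 log units; within the scatter), not beyond the scatter. Compound 3 is estimated at 12000 nM in this assay, with a range from 4000 nM to 40000 nM.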

Compound 3, half-maximal inhibitory concentration: 13700 nM
Estimate against measurement, compound 3: 1.1-fold (0.06 log units) below; the measured number falls inside the stated range.
By their numbers in this assay, from the lowest: compounds 1, 3 and 2 (each within the scatter of the next).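

In this assay, within the data shown here, (4-chlorophenyl)carbonyl in place of (3-fluorophenyl)sulfonyl on an amine nitrogen gives no change at the digits printed from compound 1 to compound 3 (within the scatter), the first comparison of a carbonyl with a sulfonyl at this place. The other single-place reading, (((4-chlorophenyl)carbonyl)amino)methyl in place of ((4-chlorophenyl)sulfonyl)amino on a saturated chain carbon, gives a 1.4-fold lower number from compound 2 to compound 3 (0.13 log units; within the scatter), so all three compounds remain within the scatter of one another and the sulfonyl-to-carbonyl exchange opens no separation here. Nothing available bears on the cause of this flat result.

Open, from the compounds shown here alone, is whether a carboxylic acid or a primary amine on the amine nitrogen in place of the aryl carbonyl would move the number in this assay beyond the scatter. Also open, going by these compounds, is whether a longer chain would do so with the (4-chlorophenyl)carbonyl group held fixed.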